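The source may hold more compounds than are shown below. What is called first, only, known or untested is meant among the compounds shown, and "the series" means these compounds.

Of the compounds shown here, three sharing one core have been measured in a functional assay on HeLa cells (Homo sapiens) for inhibition, read by MTT assay, with a stated time of 72 h; a higher number here means a weaker inhibitor, a lower number a stronger inhibitor. Compound 1 `CC(C)c1ccc(C(=O)/C=C/C(=O)O)c(C(C)C)c1` gives 4060 nM. Compound 2 `O=C(O)/C=C/C(=O)c1ccc(Cl)cc1Cl` gives 62900 nM in this assay. Compound 3 `CC(C)(C)c1ccc(C(=O)/C=C/C(=O)O)cc1` gives 5100 nM in this assay. Among these three numbers compound 3 stands second highest; its nearest neighbour is compound 1, whose number differs from it only within the scatter, and its furthest is compound 2, whose number lies beyond the scatter on the higher side.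

Compound 4 `CCc1ccc(C(=O)/C=C/C(=O)O)cc1` has not yet been measured. It differs from compound 3 in a single place:

ethyl in place of tert-butyl on an aromatic carbon

Among the measured compounds shown here, no pair of measured compounds differing in just one place is available, so the size of this step cannot be read from the measured numbers and can only be expected. Because compound 3 gives 5100 nM while compound 1, which also carries branched alkyl groups on its ring, gives 4060 nM, the expectation is that replacing the larger alkyl group by a smaller one changes the number only modestly, and the step from compound 3 to compound 4 is expected to be a 1.4-fold higher number from compound 3 to compound 4 (0.14 log units; within the scatter), tending toward a higher number but not clearly beyond the scatter. Compound 4 is therefore estimated at 7000 nM in this assay, with a range from 3000 nM to 20000 nM.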

Compound 4, half-maximal inhibitory concentration: 27800 nM
The estimate for compound 4 lay 4.0-fold (0.60 log units) below the measured number, outside the stated range (above it).
By their numbers in this assay, from the lowest: compounds 1 and 3 (each within the scatter of the next); then compound 4; then compound 2.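

In this assay, among the compounds shown here, the replacement of tert-butyl by ethyl on this aromatic carbon gives a 5.5-fold higher number from compound 3 to compound 4 (0.74 log units; beyond the scatter) and is the first single-place step that can be read directly in this set; the earlier compounds offered no such pair. It shows that this position is sensitive to the alkyl group it carries, since the number moves beyond the usual scatter toward a weaker inhibitor when 4 heavy atoms give way to 2 heavy atoms, although both groups are carbon only, with no ring, no hydrogen-bond donors or acceptors and no net charge. Nothing measured here bears on why the step takes this size, so the result stands without an explanation.

The compounds shown leave open whether the number would climb further with methyl or a plain hydrogen on this carbon, or whether isopropyl would fall closer to tert-butyl or to ethyl. They also leave open how a longer chain such as n-butyl, or a group holding other atoms such as methoxy or an amine, would behave in the same place.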